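Removing the 4-formylphenyl group from compound 2

A few compounds are considered here, and "the series" means these few. Any claim that something is new, unique, unknown or untested is made for them only; others in the source may bear on it.

In a functional assay on HuCC-A1 cells (Homo sapiens) for cytotoxicity, read by MTT assay, with a stated time of 48 h (on this read-out lower numbers stand for stronger inhibition and higher numbers for weaker inhibition), compound 2 `COc1cc2c(cc1OC)CN(S(=O)(=O)c1ccc(-n3cc(COc4ccc(C=O)cc4)nn3)cc1)CC2` gives 31100 nM. This lies within the scatter of compound 3 `O=c1cc(OCc2cn(-c3ccc(S(=O)(=O)N4CCc5ccccc5C4)cc3)nn2)c2ccccc2o1` at 24800 nM. Compound 1 `COC(=O)c1ccccc1OCc1cn(-c2ccc(S(=O)(=O)N3CCc4ccccc4C3)cc2)nn1`, at 630 nM, is the strongest of the three, and the gap to compound 2 is well beyond the scatter.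

Compound 4 `COc1cc2c(cc1OC)CN(S(=O)(=O)c1ccc(-n3cc(CO)nn3)cc1)CC2` differs from compound 2 in one place: hydrogen in place of 4-formylphenyl on an oxygen on a saturated carbon. The (4-formylphenoxy)methyl group thus becomes hydroxymethyl. Among the measured compounds shown here, only one measured step bears on this oxygen: a 39-fold higher number from compound 1 to compound 3 (1.60 log units; beyond the scatter). That large step shows that the group held there can matter greatly in this assay. However, it exchanges one aromatic group for another on a different core, and no measured step removes the group outright. It therefore fixes neither the size nor the direction of the change expected here. With little evidence either way, no step beyond the scatter is expected. The estimated change is a 1.1-fold higher number from compound 2 to compound 4 (0.05 log units; within the scatter). For compound 4 the estimated value is 35000 nM, with an expected range of 10000 nM to 120000 nM.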

Compound 4, half-maximal inhibitory concentration: 72000 nM
Estimate against measurement, compound 4: 2.1-fold (0.31 log units) below; the range from low to high includes it.
By their numbers in this assay, from the lowest: compound 1; then compounds 3 and 2 (each within the scatter of the next); then compound 4.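

In this assay, taking the 4-formylphenyl group off this oxygen gives a 2.3-fold higher number from compound 2 to compound 4 (0.36 log units; beyond the scatter). Among the compounds shown here, earlier, the only step at this oxygen, a 39-fold higher number from compound 1 to compound 3 (1.60 log units; beyond the scatter), exchanged one aromatic group for another; this one removes the group outright and shows that, on this core, hydroxymethyl gives a higher number than (4-formylphenoxy)methyl. The step is modest, though beyond the scatter, and nothing shown here accounts for it.

Going by these compounds, how a plain phenyl, or a phenyl bearing a carboxylic acid or an amine in place of the formyl group, would read on this oxygen remains open, so the part played by the formyl group itself cannot be separated from that of the ring. On these data alone, whether the same removal on the core of compound 1 would give a step of similar size and direction also remains open.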